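A Second Chloro on the Aromatic Ring of Compound 2

The compounds below may be only part of what the source reports. "The series", "measured", "known", "first", "only" and "open" are said of these compounds alone.

Measured compounds and their growth inhibition:
compound 1, `O=C1NC(=S)/C(=C/c2ccc(Cl)cc2)S1` — 22.3%
compound 2, `O=C1NC(=S)/C(=C/c2cccc(Cl)c2)S1` — 18.8%
compound 3, `O=C1NC(=S)/C(=C/c2cccc(F)c2)S1` — 20.9%

In a functional assay on HEp-2 cells (Homo sapiens) for cytotoxicity, read by MTT assay, with a stated time of 72 h, tested at 10 ug/mL (a lower number here means less inhibition of growth, a higher number more inhibition of growth at the concentration tested), compound 2 gives 18.8%, the lowest of the three numbers, though none of the three stands apart from the others. Its nearest neighbour is compound 3, with 20.9%; the step of a number 2.1 percentage points higher from compound 2 to compound 3 (within the scatter) lies within the scatter. The furthest is compound 1, with 22.3%, also within the scatter of compound 2.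

Compound 4, `O=C1NC(=S)/C(=C/c2ccc(Cl)c(Cl)c2)S1`, differs from compound 2 by chloro in place of hydrogen on an aromatic carbon, ortho to a chloro group and para to a group of 8 heavy atoms. Among the compounds with values here, no measured step adds a chloro; the only measured step, from compound 2 to compound 3, swaps one halogen for another and stays within the scatter, and compounds 1 and 2, each carrying a single chloro, sit within the scatter of each other. The account therefore expects no step beyond the scatter in this assay, giving a number 3.2 percentage points higher from compound 2 to compound 4 (within the scatter) as the estimated change. Compound 4 is estimated at 22%, expected between 10% and 38%.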

Compound 4, percent growth inhibition at one concentration: 16.4%
Compound 4: middle estimate off by 5.6 percentage points, on the high side, and the stated range covers the measured number.
By their numbers in this assay, from the lowest: compounds 4, 2, 3 and 1 (each within the scatter of the next).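

Chloro in place of hydrogen on an aromatic carbon, ortho to a chloro group and para to a group of 8 heavy atoms, is the first measured step that adds a group instead of exchanging one halogen for another, and in this assay it gives a number 2.4 percentage points lower from compound 2 to compound 4 (within the scatter) and no step beyond the scatter. The second step, a number 5.9 percentage points lower from compound 1 to compound 4 (within the scatter) and is again chloro in place of hydrogen on an aromatic carbon, so neither reading of the second chloro leaves the scatter. Nothing measured here offers a reason for this result.

The compounds shown leave open whether an amine, a carboxylic acid or a methoxy group at this place on compound 2 would give a step beyond the scatter. They also leave open whether fluoro as the added group would read as chloro does here.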